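Replacing the hydroxyamino group of compound 2

A few compounds are considered here, and "the series" means these few. Any claim that something is new, unique, unknown or untested is made for them only; others in the source may bear on it.

Measured compounds:
compound 1, `CCC(C)C(NC(=O)NO)C(=O)NC1CCCCC1`, a limit of the assay: > 100000 nM
compound 2, `CCC(C)C(NC(=O)NO)C(=O)NC(c1ccccc1)c1ccccc1`, a limit of the assay: > 100000 nM
compound 3, `CCC(C)C1NC(=O)N(C2CCCC2)C1=O`, a limit of the assay: > 100000 nM

All three were tested in a functional assay on HeLa cells (Homo sapiens) for inhibition; a higher number here means a weaker inhibitor, a lower number a stronger inhibitor. For compound 2 the result is only a limit of the assay, not a number, namely > 100000 nM. Compound 2 therefore stands nowhere in particular among the shown values: every one of them sits at the same limit, (the limit of > 100000 nM in this assay, at which 3 of the 3 values shown sit). Among the measured compounds shown here, no step between two measured compounds can be read from this set, so there is no measured change to scale anything against.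

Compound 4, `CCC(C)C(NC(=O)n1nnc2ccccc21)C(=O)NC(c1ccccc1)c1ccccc1`, differs from compound 2 in one place: a group of 9 heavy atoms (6 carbon, 3 nitrogen; one five-membered aromatic ring with 3 hetero atoms, one six-membered aromatic ring of carbon only) in place of a group of 2 heavy atoms (1 nitrogen, 1 oxygen; no ring), on a carbonyl carbon.

For the measured compounds named here, with compound 2 at the limit and no measured step to guide the direction, the expected step from compound 2 to compound 4 in this assay is a number no higher from compound 2 to compound 4 (the limit leaves the size open), which is no movement beyond the scatter, and most likely compound 4 will again return only a limit. The estimate for compound 4 in this assay is accordingly 100000 nM, with a range from 20000 nM to 500000 nM.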

Compound 4, half-maximal inhibitory concentration: 60000 nM
Beside the measured number, compound 4's estimate is 1.7-fold (0.22 log units) above it; low and high end bracket the measured number.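

Among the compounds shown here, compound 4 is the first compound in this set to give a number rather than a limit in this assay, at 60000 nM, so a reading in this assay does not depend on the hydroxyamino group at this carbonyl carbon, even though the entering group has 0 hydrogen-bond donors. Putting the group with one five-membered aromatic ring with 3 hetero atoms and one six-membered aromatic ring of carbon only in place of hydroxyamino gives an at least 1.6-fold lower number from compound 2 to compound 4 (0.22 log units; that floor lies within the scatter). The value of compound 2, > 100000 nM, is a limit of the assay, so that step is only a floor, and its full size cannot be read.

Going by these compounds, all other steps cannot be read, and the set still offers little to compare: the limit of > 100000 nM in this assay, at which 3 of the 4 values shown sit. Whether a smaller group such as an amine or a carboxylic acid on this carbonyl carbon would also give a number stays open, as does whether the five-membered ring alone, without the six-membered ring, would be enough.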